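Ethyl for 4-bromophenyl on the ring nitrogen

A few compounds are considered here, and "the series" means these few. Any claim that something is new, unique, unknown or untested is made for them only; others in the source may bear on it.

Compound 3 `COc1ccc(Cc2nn(-c3ccc(Br)cc3)c(=O)c3ccccc23)cc1OC` sits at the edge of a functional assay on aorta with Alpha-1D adrenergic receptor (Rattus norvegicus) as the target; a lower number here means that less compound is needed, a higher number that more compound is needed for the effect: compound 3 gives > 100000 nM, which is a limit of the assay and not a number (the limit of > 100000 nM in this assay, at which 1 of the 3 values shown sits). Compound 1 `COc1ccc(Cc2nn(C(C)(C)C)c(=O)c3ccccc23)cc1OC` gives 10000 nM in this assay, and the step of an at least 10-fold higher number from compound 1 to compound 3 (1.00 log units; beyond the scatter) shows the size of swapping tert-butyl for 4-bromophenyl. Compound 2 `CCn1nc(Cc2ccc(OC)cc2)c2ccccc2c1=O` has "not determined" (no result reported) in this assay. Compound 4 `CCn1nc(Cc2ccc(OC)c(OC)c2)c2ccccc2c1=O` carries the change (ethyl in place of 4-bromophenyl on an aromatic nitrogen). Among the measured compounds shown here, the only measured step at this position is an at least 10-fold higher number from compound 1 to compound 3 (1.00 log units; beyond the scatter); it concerns tert-butyl rather than ethyl, so it bears only loosely. Since compound 1 gives 10000 nM with a small alkyl on the same nitrogen, compound 4 is expected near that, a step of an at least 8.3-fold lower number from compound 3 to compound 4 (0.92 log units; beyond the scatter) downward. Estimated for compound 4: 12000 nM, range 3000 nM to 60000 nM.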

Compound 4, half-maximal effective concentration: 5300 nM
Compound 4: middle estimate off by 2.3-fold (0.35 log units), on the high side; the measured number falls inside the stated range.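

With an at least 18-fold lower number from compound 3 to compound 4 (1.27 log units; beyond the scatter) in this assay, the two alkyl groups on this nitrogen now stand apart from 4-bromophenyl, not just tert-butyl alone. Compound 3 remains a limit and not a number, so that step has no upper end: the limit of > 100000 nM in this assay, at which 1 of the 4 values shown sits. The step of a 1.9-fold lower number from compound 1 to compound 4 (0.28 log units; within the scatter) gives no separation between ethyl and tert-butyl at this position.

Open, from the compounds shown here alone, is whether plain phenyl without the bromine, or benzyl, behaves like compound 3 or like the alkyl compounds. Also open, going by these compounds, is how a longer chain ending in an amine would read here.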